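A few compounds are considered here, and "the series" means these few. Any claim that something is new, unique, unknown or untested is made for them only; others in the source may bear on it.

Among the compounds with values here, compound 1 `C#CCn1cc(C(=O)NC(CC(=O)Nc2ccccn2)c2ccccc2)c(=O)c2ccc(Cl)nc21` and its companion compound 2 `C#CCn1cc(C(=O)NC(CC(=O)NC2CCCC2)c2ccccc2)c(=O)c2ccc(Cl)nc21` are the two measured members. In a functional assay on K562 cells (Homo sapiens) for cytotoxicity, read by MTT assay, with a stated time of 72 h (on this read-out lower numbers stand for stronger inhibition and higher numbers for weaker inhibition), compound 1 gives 5900 nM, while compound 2 gives 6800 nM. Within the data shown here, the only measured step, a 1.2-fold higher number from compound 1 to compound 2 (0.06 log units; within the scatter), concerns the amide-type nitrogen and leaves the shared core untouched; the two numbers sit within the scatter of each other, and compound 1 serves as the reference point.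

Compound 3 `C#CCn1cc(C(=O)NC(CC(=O)Nc2ccccn2)c2ccccc2)c(=O)c2cc(F)c(Cl)nc21` differs from compound 1 by fluoro in place of hydrogen on an aromatic carbon. Among the measured compounds shown here, no measured step bears on a change at this position of the shared core; the one step on record, from compound 1 to compound 2, is at a different part of the molecule and is itself within the scatter. The expectation for compound 3 in this assay is accordingly a step of no more than the scatter, a 1.2-fold lower number from compound 1 to compound 3 (0.07 log units; within the scatter). Compound 3 is estimated at 5000 nM, with a range from 2000 nM to 15000 nM.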

Compound 3, half-maximal inhibitory concentration: > 10000 nM
Compound 3 gave a limit, no number (the forecaster's own chance of this, stated with the estimate: 5%); middle value at least 2.0-fold (0.30 log units) from the limit.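

Compound 3 stands only as a limit, not a number, in this assay: the limit of > 10000 nM in this assay, at which 1 of the 3 values shown sits. Within the data shown here, the step for fluoro in place of hydrogen on this aromatic carbon, ortho to a chloro group, reads an at least 1.6-fold higher number from compound 1 to compound 3 (0.22 log units; that floor lies within the scatter), and it is the first reading at this position of the shared core. On these data alone, it shows that this single added fluoro atom gives no lower number than hydrogen here, though its printed floor does not establish a step beyond the scatter, and the true size of the step stays unknown behind the limit.

How far the number rises with fluoro cannot be told from a limit. As far as these compounds go, whether an amine or a methoxy group on the same aromatic carbon would read like hydrogen or like fluoro remains open, as does the effect of fluoro with the cyclopentyl amide of compound 2.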